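Trading One Chloro for Hydrogen on a Low-Number Compound

This account rests on a few compounds, and the source may have more. Where it says the series, first, only, none or still open, it means among the compounds named here.

Measured so far:
Compound 1, `Cc1nc(-c2ccccc2)sc1C(=O)CSc1nc(N)c(C#N)c(-c2ccccc2)n1`: 9.5%
Compound 2, `Cc1nc(-c2ccc(Cl)cc2)sc1C(=O)CSc1nc(N)c(C#N)c(-c2ccc(Cl)cc2)n1`: -3.7%

Both compounds share the same core and differ only in whether each of the two six-membered aromatic rings of carbon only carries a chloro group. In an assay on membranes from CHO cells for displacement of a labelled ligand from adenosine receptor A1 (Homo sapiens), read by scintillation counting, with a stated time of 60 min, tested at 1 uM (a higher number here means more inhibition at the concentration tested (going by the name of the read-out), a lower number less inhibition), compound 1 gives 9.5%, and compound 2 gives -3.7%. Compound 2 stands lowest of the two numbers; its nearest neighbour is compound 1, which sits higher by a margin beyond the usual scatter. Neither value points to much inhibition at the concentration tested.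

Compound 3, `Cc1nc(-c2ccc(Cl)cc2)sc1C(=O)CSc1nc(N)c(C#N)c(-c2ccccc2)n1`, keeps one of the two chloro groups and drops the other. The change from compound 2 to compound 3 is hydrogen in place of chloro on an aromatic carbon, on an aromatic carbon of a six-membered aromatic ring of carbon only, para to a large group. For the measured compounds named here, no measured pair shows this change alone, so the step has to be guessed from the two values above. Compound 3 lies between compound 1 and compound 2 in structure, and because compound 1 gives 9.5%, a small rise from compound 2 seems the most likely outcome. The expected step of a number 6.7 percentage points higher from compound 2 to compound 3 (within the scatter) is within the scatter. Compound 3 is estimated at 3%, within -9% to 15%.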

Compound 3, a percentage reported as inhibition, at one concentration (the size of the read-out at that concentration, not a potency): 8.7%
The estimate for compound 3 lay 5.7 percentage points below the measured number, within the range that was stated.
By their numbers in this assay, from the lowest: compound 2; then compounds 3 and 1 (each within the scatter of the next).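

Removing the chloro from just one of the two rings gives a measurable step in this assay: a number 12.4 percentage points higher from compound 2 to compound 3 (beyond the scatter). For the compounds shown here, this separates the two chloro groups for the first time, showing that this 4-chlorophenyl to phenyl change alone moves the number, although compound 3 at 8.7% still shows little inhibition at the concentration tested. The chloro on the other ring gives a different picture, since placing it on an otherwise unchanged structure yields only a number 0.8 percentage points lower from compound 1 to compound 3 (within the scatter) and no real change can be claimed for it; the data offer no measured explanation for this difference between the two positions.

On these data alone, it remains open whether the step at the first position would look the same on a compound whose other ring carries no chloro. Also open, as far as these compounds go, is what a fluoro, a methoxy, an amine or a carboxylic acid would do in place of the chloro on either ring, and whether any such group would lift the number well clear of this low range.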